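The compounds below may be only part of what the source reports. "The series", "measured", "known", "first", "only" and "open" are said of these compounds alone.

Compound 1, with the structure `Nc1nc2[nH]c(CCSCCC(=O)NCc3ccccn3)cc2c(=O)[nH]1`, is the starting point of this small set. In a functional assay on KB cells (Homo sapiens) for antiproliferative activity, read by MTT assay, with a stated time of 72 h, in the presence of a further agent that is not named here (a higher number here means a weaker inhibitor, a lower number a stronger inhibitor), compound 1 gives 8930 nM. Compound 2, with the structure `Nc1nc2[nH]c(CCSCCC(=O)NCc3ccncc3)cc2c(=O)[nH]1`, differs from compound 1 by a single change: pyridin-4-yl in place of pyridin-2-yl on a saturated chain carbon bound to an amide-type nitrogen. That change produced a 5.1-fold higher number from compound 1 to compound 2 (0.71 log units; beyond the scatter), so the rearranged pyridine ring weakened the compound noticeably.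

Compound 3, with the structure `Nc1nc2[nH]c(CCSCC(=O)NCc3ccccn3)cc2c(=O)[nH]1`, carries a shorter linker than compound 1; the difference between the two cores is not broken down here. In this assay compound 3 gives 28400 nM, and compound 2 gives 45600 nM, so compound 3 stands nearer to compound 2 than to compound 1.

Compound 4, with the structure `Nc1nc2[nH]c(CCSCC(=O)NCc3ccncc3)cc2c(=O)[nH]1`, has not yet been measured. It differs from compound 3 by pyridin-4-yl in place of pyridin-2-yl on a saturated chain carbon bound to an amide-type nitrogen, which is the same change, at the same place on a saturated chain carbon bound to an amide-type nitrogen, that separates compound 1 from compound 2. Because that change gave a 5.1-fold higher number from compound 1 to compound 2 (0.71 log units; beyond the scatter), a step of a comparable size is expected here, giving a 4.2-fold higher number from compound 3 to compound 4 (0.63 log units; beyond the scatter) from compound 3 to compound 4. The expectation rests on a single earlier example, so it is held loosely. Compound 4 is therefore expected to be a weak inhibitor in this assay, near 120000 nM, most likely between 40000 nM and 350000 nM.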

Compound 4, half-maximal inhibitory concentration: 14100 nM
Compound 4: the middle estimate sits 8.5-fold (0.93 log units) above what was measured, outside the stated range (below it).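

In this assay, putting pyridin-4-yl in place of pyridin-2-yl on the shorter linker gives a 2.0-fold lower number from compound 3 to compound 4 (0.30 log units; within the scatter), so these two compounds cannot be told apart, whereas the same change on the longer linker clearly weakened the compound. The outcome of this change therefore differs with the core that carries it, and a step seen on one of these cores cannot simply be carried over to the other: the same change on two cores in this assay, a 5.1-fold higher number (0.71 log units; beyond the scatter) from compound 1 to compound 2 and a 2.0-fold lower number (0.30 log units; within the scatter) from compound 3 to compound 4, 10-fold (1.01 log units) apart, beyond the scatter of two such steps. Among these compounds, this rests on only two pairs of compounds, and it does not show why the two cores respond differently, nor whether the change has truly no effect on the shorter linker or a small one hidden in the ordinary scatter of repeated measurements.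

The compounds shown leave open how pyridin-3-yl or a plain phenyl ring would behave at the same place, on a saturated chain carbon bound to an amide-type nitrogen, on either core. They also leave open whether a still longer chain in the linker would follow the pattern of the core of compound 1, that of the core of compound 3, or neither.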